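Isobutyl for tert-butyl on the imine nitrogen of compound 1

The compounds below may be only part of what the source reports. "The series", "measured", "known", "first", "only" and "open" are said of these compounds alone.

Measured compounds:
- compound 1, `CC(C)(C)/N=C(\S)NCCCCn1nc(-c2ccccc2)ccc1=O`: 33.6%
- compound 2, `C/N=C(/NC#N)NCCCn1nc(-c2ccccc2)c(C)cc1=O`: 17.2%
- compound 3, `C/N=C(\S)NCCCn1nc(-c2ccccc2)ccc1=O`: 38.9%

In a functional assay on the whole organism with Rattus norvegicus as the target, at a dose of 100 mg/kg (a higher number here means more inhibition at the dose given (going by the name of the read-out), a lower number less inhibition), compound 1 gives 33.6%, the second highest of the three numbers. Its nearest neighbour is compound 3, whose value in this assay sits within the usual scatter of compound 1, so no order between the two is claimed. Compound 2 is the furthest, with a number beyond the scatter below compound 1.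

Compound 4 is `CC(C)C/N=C(\S)NCCCCn1nc(-c2ccccc2)ccc1=O`, not yet measured in this assay. The change from compound 1 is isobutyl in place of tert-butyl on a double-bonded nitrogen. For the measured compounds named here, no pair of measured compounds differs in one place, so no measured step describes a change of this kind, and the three values give no trend that rests on this part of the molecule. The rest of compound 4 is kept from compound 1.

Compound 4 is expected to stay within the usual scatter of compound 1, with the estimated step of a number 1.4 percentage points higher from compound 1 to compound 4 (within the scatter) counting for little. The estimate for compound 4 in this assay is 35%, in the range 17% to 53%.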

Compound 4, a percentage reported as inhibition, in the whole organism at one dose (the size of the read-out at that dose, not a potency): 35.8%
Estimate against measurement, compound 4: 0.8 percentage points below, and the stated range covers the measured number.
By their numbers in this assay, from the lowest: compound 2; then compounds 1, 4 and 3 (each within the scatter of the next).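

In this assay, for the compounds shown here, isobutyl in place of tert-butyl on the double-bonded nitrogen gives the first step that can be read at one place: a number 2.2 percentage points higher from compound 1 to compound 4 (within the scatter). Exchanging these two groups, which have the same atoms joined differently, therefore does not separate the compounds at the dose given, and this reading gives the size of the effect at that dose, not a potency. Nothing measured here bears on the reason for this result.

Still open, as far as these compounds go, is whether a cyclohexyl or benzyl group on the double-bonded nitrogen would shift the number beyond the usual scatter around compound 1. From the compounds shown here alone, the exchange also rests on a single pair, so whether it behaves the same way with a different chain to the shared core remains unknown.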